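Swapping a sulfonyl for a sulfanyl on a weak inhibitor

This account rests on a few compounds, and the source may have more. Where it says the series, first, only, none or still open, it means among the compounds named here.

Measured in a functional assay on DU-145 cells (Homo sapiens) for inhibition, read by trypan blue exclusion, with a stated time of 96 h; a lower number here means a stronger inhibitor of growth, a higher number a weaker inhibitor of growth:
compound 1 `O=C(/C(=C\c1c(O)cc(O)cc1O)S(=O)(=O)c1ccccc1Br)c1ccc(Br)cc1`: 50000 nM
compound 2 `Cc1ccc(S/C(=C/c2sccc2C)C(=O)c2ccc(Br)cc2)cc1`: 50000 nM
compound 3 `Cc1ccc(S(=O)(=O)/C(=C/c2c(O)cc(O)cc2O)C(=O)c2ccc(Br)cc2)cc1`: > 100000 nM (a limit, not a number)

Compound 3 has no exact value, and the only result for it is a limit. It stands at the limit of > 100000 nM in this assay, at which 1 of the 3 values shown sits.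

Compound 4 `Cc1ccc(S/C(=C/c2c(O)cc(O)cc2O)C(=O)c2ccc(Br)cc2)cc1` differs from compound 3 in one place: (4-methylphenyl)sulfanyl in place of (4-methylphenyl)sulfonyl on a double-bonded chain carbon bound to a carbonyl carbon and a double-bonded chain carbon. It has (4-methylphenyl)sulfanyl in place of (4-methylphenyl)sulfonyl on a double-bonded chain carbon bound to a carbonyl carbon and a double-bonded chain carbon.

Going by the values given here, the one measured step, an at least 2.0-fold higher number from compound 1 to compound 3 (0.30 log units; that floor lies within the scatter), changes the group on the sulfonyl sulfur and leaves the sulfonyl itself in place, so it gives no size for this swap. Compound 2 carries the same (4-methylphenyl)sulfanyl and gives 50000 nM, but it differs from compound 4 in another group, so it is only a loose guide. On that basis, a modest move to a lower number in this assay is expected, with wide uncertainty and the chance of another limit. The expected size is an at least 2.0-fold lower number from compound 3 to compound 4 (0.30 log units; that floor lies within the scatter). The estimated value for compound 4 is 50000 nM, expected to fall within 15000 nM to 150000 nM.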

Compound 4, concentration for 50% growth inhibition: > 100000 nM
Compound 4 ended at the assay's limit (the forecaster's own chance of this, stated with the estimate: 35%); middle value at least 2.0-fold (0.30 log units) away from the limit.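

In this assay, (4-methylphenyl)sulfanyl in place of (4-methylphenyl)sulfonyl gives no readable gain in growth inhibition, and the step between compound 3 and compound 4 cannot be read, as both compounds end at a limit rather than a number: the limit of > 100000 nM in this assay, at which 2 of the 4 values shown sit.

With (4-methylphenyl)sulfanyl kept in place, 2,4,6-trihydroxyphenyl in place of 3-methylthiophen-2-yl gives an at least 2.0-fold higher number from compound 2 to compound 4 (0.30 log units; that floor lies within the scatter). Changing the whole group at this position, with (4-methylphenyl)sulfanyl in place of (2-bromophenyl)sulfonyl, gives an at least 2.0-fold higher number from compound 1 to compound 4 (0.30 log units; that floor lies within the scatter), and neither of these floors alone establishes a real loss of growth inhibition.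

As far as these compounds go, the size of the swap from sulfonyl to sulfanyl remains open, since it has been seen here only in a pair where both results are limits, and a pair in which both compounds give exact numbers would be needed to measure it. Also open, from the compounds shown here alone, is what a sulfinyl group or an amine would do at this position on a double-bonded chain carbon bound to a carbonyl carbon and a double-bonded chain carbon.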